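A few compounds are considered here, and "the series" means these few. Any claim that something is new, unique, unknown or untested is made for them only; others in the source may bear on it.

Series notes. The shared core is carried by compound 1 `CCOc1ccccc1-n1nncc1CN1C(=O)C2(C(C#N)=C(N)Oc3c2c2nc4ccccc4nc2c2ccccc32)c2ccccc21`, compound 2 `N#CC1=C(N)Oc2c(c3nc4ccccc4nc3c3ccccc23)C12C(=O)N(Cc1cnnn1-c1ccc([N+](=O)[O-])cc1)c1ccccc12` and compound 3 `COc1ccc(-n2nncc2CN2C(=O)C3(C(C#N)=C(N)Oc4c(N)cc5nc6ccccc6nc5c43)c3ccccc32)cc1`, which differ in the group on an aromatic nitrogen of the five-membered aromatic ring with three nitrogens. In a functional assay on A549 cells (Homo sapiens) for antiproliferative activity, read by MTT assay, with a stated time of 48 h (a higher number here means a weaker inhibitor, a lower number a stronger inhibitor), compound 1 gives > 50000 nM, which is a limit of the assay and not a number. In this assay compound 2 likewise reaches only a limit, > 50000 nM. Compound 3 too stands at a limit in this assay, > 50000 nM. Going by the values given here, the one step that can be framed, 4-nitrophenyl in place of 2-ethoxyphenyl on an aromatic nitrogen, is a step that the two limits leave unreadable from compound 1 to compound 2; both ends sit at the limit, so neither its size nor its direction can be read. All three values shown therefore lie at the same place, (the limit of > 50000 nM in this assay, at which 3 of the 3 values shown sit).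

Compound 4 `Cc1ccc(Cl)cc1-n1nncc1CN1C(=O)C2(C(C#N)=C(N)Oc3c(N)cc4nc5ccccc5nc4c32)c2ccccc21` has not yet been measured. It differs from compound 3 as follows: 5-chloro-2-methylphenyl in place of 4-methoxyphenyl on an aromatic nitrogen. Among the compounds with values here, no measured step runs between a 4-methoxyphenyl and a 5-chloro-2-methylphenyl on this ring, and the only change of the same kind, from compound 1 to compound 2, is unreadable. Compound 3 sits at a limit, so the expected step that the limit leaves unreadable from compound 3 to compound 4 cannot be set against a number, and a value at or beyond the limit is what is expected. For compound 4 the estimate in this assay is 80000 nM, with a range from 20000 nM to 500000 nM, most likely reported only as a limit.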

Compound 4, half-maximal inhibitory concentration: > 50000 nM
Compound 4: no number, only a limit; the forecaster's own chance of this, stated with the estimate: 85%; the middle value is on the limit's open side.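

In this assay compound 4 gives > 50000 nM, a limit of the assay and not a number. No step from compound 3 to compound 4 can be read, since both stand at a limit: the limit of > 50000 nM in this assay, at which 4 of the 4 values shown sit.

The compounds shown leave open whether any group on this aromatic nitrogen gives a measurable value, and how these groups rank.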